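This account rests on a few compounds, and the source may have more. Where it says the series, first, only, none or still open, it means among the compounds named here.

In a functional assay on SW480 cells (Homo sapiens) for antiproliferative activity, with a stated time of 72 h (on this read-out lower numbers stand for stronger inhibition and higher numbers for weaker inhibition), compound 1 `O=C(COc1ccc(CN2CC=C(c3c[nH]c4ccc(F)cc34)CC2)cc1)NO` gives 1110 nM. Compound 2 `O=C(COc1ccc(CN2CC=C(c3c[nH]c4ccc(F)cc34)CC2)c(F)c1)NO` gives 3860 nM in this assay. The two differ by hydrogen in place of fluoro on an aromatic carbon, and that step is a 3.5-fold lower number from compound 2 to compound 1 (0.54 log units; beyond the scatter). Compound 3 `Cc1[nH]c2cccc(F)c2c1C1=CCC(NCc2ccc(OCC(=O)NO)cc2F)CC1` carries a different core; the difference between the cores of compound 2 and compound 3 is not broken down here. In this assay compound 3 gives "nd" (no result reported), so no number is reported for it. Compound 4 `Cc1[nH]c2ccccc2c1C1=CCC(NCc2ccc(OCC(=O)NO)cc2F)CC1` is related to compound 3 through (hydrogen in place of fluoro on an aromatic carbon). Among the measured compounds shown here, this is the same kind of change as the one from compound 2 to compound 1, not the same change: in compound 3 the fluoro sits on a ring that is part of a fused or bridged system of two rings, ortho to a fused ring and meta to a fused ring, whereas in compound 2 it sits ortho to a large group and meta to a (hydroxycarbamoyl)methoxy group. With no number for compound 3, the expectation rests only on compound 1 and compound 2, which lie in a similar range, and on the modest step of a 3.5-fold lower number from compound 2 to compound 1 (0.54 log units; beyond the scatter). Compound 4 is therefore expected to give about 2000 nM, estimated to fall between 500 nM and 8000 nM.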

Compound 4, half-maximal inhibitory concentration: 170 nM
The estimate for compound 4 lay 12-fold (1.07 log units) above the measured number; the whole stated range lies above it.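

Compound 3 has no number in this assay and compound 4 gives 170 nM, so the step between these two compounds cannot be read. The compounds shown leave open whether the fluoro on the fused ring system raises or lowers the number in this core. No measured finding bears on the value of compound 4.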